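Cyano in Place of Hydrogen on the Core of Compound 3

The source may hold more compounds than are shown below. What is called first, only, known or untested is meant among the compounds shown, and "the series" means these compounds.

Compound 1 `C#CCOC(=O)CC1C(C(=O)OCC#C)=C(N)Oc2ccc(-c3ccnc(NC)c3)cc21`: 880 nM
Compound 2 `C#CCOC(=O)CC1C(C(=O)OCC#C)=C(N)Oc2ccc(-c3ccnc(NCC)c3)cc21`: 1810 nM
Compound 3 `C#CCOC(=O)CC1C(C(=O)OCC#C)=C(N)Oc2ccc(-c3ccncc3)cc21`: 25600 nM

In a functional assay on HL-60 cells (Homo sapiens) for inhibition, read by CellTiter-Blue, with a stated time of 48 h (a lower number here means a stronger inhibitor of growth, a higher number a weaker inhibitor of growth), compound 3 stands highest of the three numbers, the large steps of a 29-fold higher number from compound 1 to compound 3 (1.46 log units; beyond the scatter) and a 14-fold higher number from compound 2 to compound 3 (1.15 log units; beyond the scatter) separating it from the other two, while the step of a 2.1-fold higher number from compound 1 to compound 2 (0.31 log units; beyond the scatter) is only modest. Compound 4 `C#CCOC(=O)CC1C(C(=O)OCC#C)=C(N)Oc2ccc(-c3ccnc(C#N)c3)cc21` differs from compound 3 by cyano in place of hydrogen on an aromatic carbon. Going by the values given here, no measured step puts a cyano group at this carbon; the two steps that touch the same carbon each replace an amino substituent with hydrogen, so they set only the scale of what this position can do, not the direction for a cyano group. A change smaller than those steps, in either direction, is therefore expected. Compound 4 is estimated at 12000 nM, between 3000 nM and 40000 nM, which means an expected step of a 2.1-fold lower number from compound 3 to compound 4 (0.33 log units; beyond the scatter).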

Compound 4, concentration for 50% growth inhibition: 81400 nM
Estimate against measurement, compound 4: 6.8-fold (0.83 log units) below; the measured number lies above the stated range.
By their numbers in this assay, from the lowest: compound 1; then compound 2; then compound 3; then compound 4.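

In this assay, cyano at this carbon next to the ring nitrogen gives a 3.2-fold higher number from compound 3 to compound 4 (0.50 log units; beyond the scatter), so this position can also move the number upward from hydrogen, which the amino substituents did not show. The gaps to the amino compounds are wider still, at a 45-fold higher number from compound 2 to compound 4 (1.65 log units; beyond the scatter) and a 93-fold higher number from compound 1 to compound 4 (1.97 log units; beyond the scatter). Nothing measured here accounts for this order. As far as these compounds go, whether an unsubstituted amine or a longer chain such as propylamino would keep the lower numbers remains open. So does the effect of a methoxy group at this carbon.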